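Phenyl ring exchange at the carbon double-bonded to nitrogen

The source may hold more compounds than are shown below. What is called first, only, known or untested is meant among the compounds shown, and "the series" means these compounds.

Working notes on the series. Compound 1 `CN(C)CCn1cnnc1-c1cc(Oc2ccc(NC(=O)N/N=C/c3c(Cl)cccc3Cl)cc2F)ccn1` gives 1410 nM in a functional assay on A549 cells (Homo sapiens) for cytotoxicity, read by MTT assay, with a stated time of 72 h; on this read-out higher numbers stand for weaker inhibition and lower numbers for stronger inhibition; compound 2 `CN(C)CCn1cnnc1-c1cc(Oc2ccc(NC(=O)N/N=C/c3ccc(F)cc3)cc2F)ccn1` gives 1790 nM in this assay; compound 3 `CN(C)CCn1cnnc1-c1cc(Oc2ccc(NC(=O)N/N=C/c3ccc(F)cc3F)cc2F)ccn1` gives 1870 nM in this assay. Compound 3 sits with the other two inside the usual scatter: a 1.3-fold higher number from compound 1 to compound 3 (0.12 log units; within the scatter), a 1.0-fold higher number from compound 2 to compound 3 (0.02 log units; within the scatter), and likewise a 1.3-fold higher number from compound 1 to compound 2 (0.10 log units; within the scatter). Compound 4 `CN(C)CCn1cnnc1-c1cc(Oc2ccc(NC(=O)N/N=C/c3ccc(O)cc3)cc2F)ccn1` differs from compound 3 by 4-hydroxyphenyl in place of 2,4-difluorophenyl on a carbon with a double bond to nitrogen. Going by the values given here, the steps bearing on this exchange are the two aryl swaps ending at compound 3, both within the scatter; no measured compound carries a 4-hydroxyphenyl at this place, so the data give no ground for a step beyond the scatter in either direction. Compound 4 is therefore expected to give 1900 nM in this assay, with a range from 800 nM to 4500 nM. The expected step is a 1.0-fold higher number from compound 3 to compound 4 (0.01 log units; within the scatter), essentially none beyond the scatter.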

Compound 4, half-maximal inhibitory concentration: 3560 nM
The estimate for compound 4 lay 1.9-fold (0.27 log units) below the measured number; low and high end bracket the measured number.
By their numbers in this assay, from the lowest: compounds 1, 2, 3 and 4 (each within the scatter of the next, the first and the last beyond it).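

Compound 4 puts a hydroxy-bearing phenyl on the carbon with a double bond to nitrogen, and in this assay this gives the only step beyond the scatter among these compounds, a modest one (a 2.5-fold higher number from compound 1 to compound 4 (0.40 log units; beyond the scatter)). Against the fluorinated phenyl groups, the same exchange stays within the scatter (a 1.9-fold higher number from compound 3 to compound 4 (0.28 log units; within the scatter); a 2.0-fold higher number from compound 2 to compound 4 (0.30 log units; within the scatter)). Nothing at hand accounts for the step from the 2,6-dichlorophenyl group.

Open, from the compounds shown here alone, is what a 4-aminophenyl or a 4-carboxyphenyl would give on this carbon, and whether a 4-methoxyphenyl would stay within the scatter of compound 4.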